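Growing the Ring-Nitrogen Substituent from Isopropyl to Isobutyl

The compounds below may be only part of what the source reports. "The series", "measured", "known", "first", "only" and "open" are said of these compounds alone.

Two measured compounds share one core: compound 1 `CN1CCCN(CCn2ccc3ccc(Br)cc32)CC1` and compound 2 `CC(C)N1CCCN(CCn2ccc3ccc(Br)cc32)CC1`. In an assay on HEK293 cells for binding affinity to 5-hydroxytryptamine receptor 7 (Homo sapiens), read by radioligand binding, tested at 1 uM (a lower number here means less inhibition, a higher number more inhibition at the concentration tested (going by the name of the read-out)), compound 1 gives 93%, and compound 2 gives 92%. Going by the values given here, the one measured step, a number 1 percentage points lower from compound 1 to compound 2 (within the scatter), came with isopropyl in place of methyl on an amine nitrogen in a ring. Compound 2 thus holds the lower of the two numbers, but its gap to compound 1 lies within the scatter, so the two read as equal.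

Compound 3 `CC(C)CN1CCCN(CCn2ccc3ccc(Br)cc32)CC1` is not yet measured. It differs from compound 2 by isobutyl in place of isopropyl on an amine nitrogen in a ring. Among the compounds with values here, the only step that bears on this change is the earlier growth of the same group on the same ring nitrogen, which gave a number 1 percentage points lower from compound 1 to compound 2 (within the scatter), a change within the scatter. One more carbon added in the same place is therefore expected to change little. For compound 3 the expected step is a number 1 percentage points lower from compound 2 to compound 3 (within the scatter). Compound 3 is estimated at 91%, with a range from 82% to 98%.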

Compound 3, a percentage reported as inhibition, at one concentration (the size of the read-out at that concentration, not a potency): 95%
For compound 3 the middle estimate is 4 percentage points below the measured one; measured number inside the range.
By their numbers in this assay, from the lowest: compounds 2, 1 and 3 (each within the scatter of the next).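

In this assay, exchanging isopropyl for isobutyl gives a number 3 percentage points higher from compound 2 to compound 3 (within the scatter), and the wider comparison with the methyl group gives a number 2 percentage points higher from compound 1 to compound 3 (within the scatter). Both steps lie within the scatter, so methyl, isopropyl and isobutyl on this amine nitrogen in the seven-membered ring read as equal, and the series now includes a group with four carbons. No supporting data accompany these numbers to explain this flat response.

All three numbers come from a single tested concentration, so they show the size of the inhibition there and not a potency, and real differences in potency could remain hidden. Also open, as far as these compounds go, is whether the number would hold with a benzyl group, a longer chain or a carboxylic acid on this nitrogen.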